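This account rests on a few compounds, and the source may have more. Where it says the series, first, only, none or still open, it means among the compounds named here.

Compound 1 `COc1cc(/C=C2\CN(C)C/C(=C\c3ccc(Br)cc3)C2=O)cc(OC)c1` gives 4270 nM in a functional assay on THP-1 cells (Homo sapiens) for cytotoxicity, read by MTT assay, with a stated time of 24 h; a higher number here means a weaker inhibitor, a lower number a stronger inhibitor.
Compound 2 `COc1cc(/C=C2\CN(C)C/C(=C\c3ccc(Cl)cc3Cl)C2=O)cc(OC)c1` gives 6070 nM in this assay.
Compound 3 `CN1C/C(=C\c2ccc(Br)cc2)C(=O)/C(=C/c2cccc([N+](=O)[O-])c2)C1` gives 7690 nM in this assay.

The three measured compounds share a central ring bearing two double-bonded chain carbons, each carrying an aromatic group. Compound 1 and compound 2 differ in one place only: 2,4-dichlorophenyl in place of 4-bromophenyl on a double-bonded chain carbon bound to a double-bonded ring carbon. This change produced a 1.4-fold higher number from compound 1 to compound 2 (0.15 log units; within the scatter), a step that stays within the usual scatter of the method. Compound 3 carries a different core from compound 1, and the difference between the two cores is not broken down here; what the two values show is that compound 3 and compound 1 lie within the scatter of each other in this assay.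

Compound 4 `CN1C/C(=C\c2cccc([N+](=O)[O-])c2)C(=O)/C(=C/c2ccc(Cl)cc2Cl)C1` has not been measured. It stands to compound 3 as compound 2 stands to compound 1: 2,4-dichlorophenyl in place of 4-bromophenyl on a double-bonded chain carbon bound to a double-bonded ring carbon. The place of the change is the same in both pairs, so it is the same change, made on a different core. For the measured compounds named here, since the only measured instance of this change, from compound 1 to compound 2, gave a 1.4-fold higher number from compound 1 to compound 2 (0.15 log units; within the scatter), a step of about the same size is expected here, namely a 1.4-fold higher number from compound 3 to compound 4 (0.15 log units; within the scatter) in this assay. On that basis compound 4 is estimated at 10800 nM in this assay, with a likely range from 5400 nM to 21600 nM, the range being wide because compound 2 and compound 1 differ by a step that itself lies within the scatter, so the direction of the step is not settled.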

Compound 4, half-maximal inhibitory concentration: 3560 nM
Compound 4: the middle estimate sits 3.0-fold (0.48 log units) above what was measured; measured number below the stated range.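

In this assay, putting 2,4-dichlorophenyl in place of 4-bromophenyl on a double-bonded chain carbon bound to a double-bonded ring carbon gave a 2.2-fold lower number from compound 3 to compound 4 (0.33 log units; beyond the scatter), and the two instances of this change do not agree: the same change on two cores in this assay, a 1.4-fold higher number (0.15 log units; within the scatter) from compound 1 to compound 2 and a 2.2-fold lower number (0.33 log units; beyond the scatter) from compound 3 to compound 4, 3.1-fold (0.49 log units) apart, beyond the scatter of two such steps. This shows that, in this series, the step seen on one core cannot be carried to the other as a fixed amount, since the same exchange of groups gave steps that differ by more than the scatter. It does not show why they differ or which part of the core matters, and it does not establish a rule for either core, as each core offers a single pair, and the step on the core of compound 1 is too small to settle even a direction.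

The compounds shown leave open whether the change would behave on a third core as it did on either of these two, or whether the step seen on the core of compound 3 would hold with other partners on that core. They also leave open how a phenyl ring carrying an amine or a carboxylic acid would fare in the same place on each core, and whether such a group would give steps that agree from one core to the other.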